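Compound 3 to compound 4: 1,3-thiazol-2-yl replacing 3,5-dimethylphenyl

A few compounds are considered here, and "the series" means these few. Any claim that something is new, unique, unknown or untested is made for them only; others in the source may bear on it.

In a functional assay on A549 cells (Homo sapiens) for cytotoxicity (a higher number here means that more compound is needed for the effect, a lower number that less compound is needed), compound 1 `COC1=C(C)C(=O)/C(=C(O)/C=C/c2ccc(O)cc2)C(=O)C1(C)C` gives 3.1 ug/mL, compound 2 `COC1=C(C)C(=O)/C(=C(O)/C=C/c2ccc(C)cc2)C(=O)C1(C)C` gives 4.3 ug/mL and compound 3 `COC1=C(C)C(=O)/C(=C(O)/C=C/c2cc(C)cc(C)c2)C(=O)C1(C)C` gives 4.3 ug/mL. Compound 3 is level with compound 2, and all three values lie within the scatter of one another.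

Compound 4 `COC1=C(C)C(=O)/C(=C(O)/C=C/c2nccs2)C(=O)C1(C)C` differs from compound 3 as follows: 1,3-thiazol-2-yl in place of 3,5-dimethylphenyl on a double-bonded chain carbon bound to a double-bonded chain carbon. Two measured steps act at this same place: a 1.4-fold higher number from compound 1 to compound 3 (0.14 log units; within the scatter) and no change at the digits printed from compound 2 to compound 3 (within the scatter). A third, on the aromatic ring, is a 1.4-fold higher number from compound 1 to compound 2 (0.14 log units; within the scatter). All are small, but none brings in a ring with hetero atoms, so they guide the estimate only loosely.

No change beyond the scatter is expected, and the estimated step is a 1.1-fold lower number from compound 3 to compound 4 (0.03 log units; within the scatter). For compound 4 the expected value is 4 ug/mL, within a range of 2 ug/mL to 8 ug/mL.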

Compound 4, concentration for half-maximal effect: 3.5 ug/mL
Estimate against measurement, compound 4: 1.1-fold (0.06 log units) above, within the range that was stated.
By their numbers in this assay, from the lowest: compounds 1, 4, 2 and 3 (each within the scatter of the next).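

In this assay the 1,3-thiazol-2-yl group is the only ring with hetero atoms among the compounds shown at this place, and the steps to it stay small: a 1.2-fold lower number from compound 3 to compound 4 (0.09 log units; within the scatter) and a 1.2-fold lower number from compound 2 to compound 4 (0.09 log units; within the scatter) and a 1.1-fold higher number from compound 1 to compound 4 (0.05 log units; within the scatter). Among these four compounds, a five-membered aromatic ring with 2 hetero atoms therefore gives a number within the scatter of all three substituted phenyl groups. No measurement shown offers an explanation for this.

Still open, from the compounds shown here alone, is whether an amine or a carboxylic acid on the ring, or a longer chain at this place, would move the number beyond the scatter.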